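Benzoxazole for benzothiazole in the cytotoxicity series

The source may report more compounds than this note shows. Statements on the series, on what has been measured and on what is new or still open speak of the compounds shown alone.

Working notes on the series. Compound 1 `Cc1ccc(-c2nc3ccccc3o2)cc1NC(=O)c1cc([N+](=O)[O-])ccc1Cl` reaches only a limit in an ADME assay on Raji cells (Homo sapiens) for cytotoxicity, with a stated time of 72 h (on this read-out lower numbers stand for an effect already at smaller amounts and higher numbers for an effect only at larger amounts of compound), reported as > 14000 nM (the limit of > 14000 nM in this assay, at which 1 of the 2 values shown sits). Compound 2 `O=C(Nc1cccc(-c2nc3ccccc3s2)c1)c1cc([N+](=O)[O-])ccc1Cl` likewise reaches only a limit in this assay, reported as > 27000 nM (the limit of > 27000 nM in this assay, at which 1 of the 2 values shown sits). Compound 2 thus stands at a limit, as does the other value shown. Compound 3 `O=C(Nc1cccc(-c2nc3ccccc3o2)c1)c1cc([N+](=O)[O-])ccc1Cl` differs from compound 2 by 1,3-benzoxazol-2-yl in place of 1,3-benzothiazol-2-yl on an aromatic carbon. Within the data shown here, no step between measured compounds exists; compound 1 carries the entering group on the shared core and also reaches only a limit. The change is expected to bring no step beyond the scatter, a step that the limit leaves unreadable from compound 2 to compound 3. For compound 3 the estimate in this assay is 30000 nM, within 10000 nM to 100000 nM, most likely again only a limit.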

Compound 3, half-maximal effective concentration: > 25000 nM
Compound 3: only a limit was reported (the forecaster's own chance of this, stated with the estimate: 85%); the middle value lies beyond the limit too.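

Among these compounds, compound 1, compound 2 and compound 3 all reach only limits in this assay and no step among them can be read. The compounds shown leave open whether 1,3-benzoxazol-2-yl in place of 1,3-benzothiazol-2-yl, or hydrogen in place of methyl, changes the half-maximal effective concentration at all.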